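This account rests on a few compounds, and the source may have more. Where it says the series, first, only, none or still open, it means among the compounds named here.

Measured so far in the paw edema test:

Compound 1, `COc1ccc(-n2nc(C(=O)Nc3ccccc3OC)nc2-c2cc(OC)c(OC)c(OC)c2)cc1`, gives 44%.
Compound 2, `COc1ccc(-n2nc(C(=O)Nc3ccc(C)cc3)nc2-c2cc(OC)c(OC)c(OC)c2)cc1`, gives 88%.
Compound 3, `COc1ccc(-n2nc(C(=O)Nc3cccc(F)c3)nc2-c2cc(OC)c(OC)c(OC)c2)cc1`, gives 106%.

All three share one core and differ only in the ring carried on the amide-type nitrogen. In a functional assay on the whole organism for inhibition, with Rattus norvegicus as the target, read by paw edema, with stated times of 30 min and 3 h, at a dose of 0.28 mmol/kg by the oral route (a higher number here means more inhibition at the dose given (going by the name of the read-out), a lower number less inhibition), compound 3 stands highest of the three numbers: a number 18 percentage points higher from compound 2 to compound 3 (beyond the scatter), and a number 62 percentage points higher from compound 1 to compound 3 (beyond the scatter). The remaining step, a number 44 percentage points higher from compound 1 to compound 2 (beyond the scatter), shows that swapping this ring alone can move the read-out a long way.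

Compound 4, `COc1ccc(-n2nc(C(=O)Nc3ccc(O)cc3)nc2-c2cc(OC)c(OC)c(OC)c2)cc1`, has not yet been measured. It differs from compound 3 in one place: 4-hydroxyphenyl in place of 3-fluorophenyl on an amide-type nitrogen. None of the three measured steps exchanges a fluorine-bearing ring for a hydroxyl-bearing one, so they bear on this change only indirectly, by showing that every ring swap at this position has shifted the number well beyond the scatter, in steps ranging from modest to large. Because compound 3 already holds the top value at 106%, and every other ring tried here sits lower, the expected direction for compound 4 is downward, with a step of modest to large size, a number 31 percentage points lower from compound 3 to compound 4 (beyond the scatter). The estimate for compound 4 is therefore 75%, expected to fall between 45% and 105%.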

Compound 4, a percentage reported as inhibition, in the whole organism at one dose (the size of the read-out at that dose, not a potency): 74%
Compound 4: middle estimate off by 1 percentage points, on the high side; the range from low to high includes it.
By their numbers in this assay, from the lowest: compound 1; then compound 4; then compound 2; then compound 3.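

In this assay, for the compounds shown here, moving to the 4-hydroxyphenyl ring on the amide-type nitrogen from the 3-fluorophenyl ring gives a number 32 percentage points lower from compound 3 to compound 4 (beyond the scatter), whereas moving to it from the 2-methoxyphenyl ring gives a number 30 percentage points higher from compound 1 to compound 4 (beyond the scatter), so this ring sits inside the range set by the earlier compounds and tops neither end. The narrowest comparison is hydroxy in place of methyl on an aromatic carbon, which gives a number 14 percentage points lower from compound 2 to compound 4 (beyond the scatter), showing that even this single small exchange on the ring is enough to shift the read-out. Nothing available explains why these rings rank as they do.

The 3-fluorophenyl and 4-hydroxyphenyl names differ in both the group and its printed ring position, so the compounds shown cannot separate those two changes; 4-fluorophenyl and 3-hydroxyphenyl rings would be the comparisons that could. As far as these compounds go, it also stays open whether an amine or a carboxylic acid on this ring would behave like the hydroxy group, and whether a chlorine would behave like the fluorine.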